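From propanoyl to methylsulfonyl on the aromatic nitrogen

The compounds below may be only part of what the source reports. "The series", "measured", "known", "first", "only" and "open" are said of these compounds alone.

In a functional assay on the whole organism with Mus musculus as the target (on this read-out higher numbers stand for an effect only at larger amounts of compound and lower numbers for an effect already at smaller amounts), compound 1 (`Cc1c(C)c2c(c(C)c1N)CC(C)(C)O2`) gives 7.8 mg/kg, and compound 2 (`CCCSCC1(C)Cc2c(C)c(N)c(C)c(C)c2O1`) gives 24.6 mg/kg. Compound 3 (`CCC(=O)Nc1c(C)c(C)c2c(c1C)CC(C)(C)O2`) stands at > 100 mg/kg, which is a limit of the assay and not a number. Compound 4 (`Cc1c(C)c2c(c(C)c1NS(C)(=O)=O)CC(C)(C)O2`), not yet measured, carries methylsulfonyl in place of propanoyl on a nitrogen on an aromatic ring. The step that bears most directly is the large one at that same nitrogen, an at least 12-fold higher number from compound 1 to compound 3 (1.10 log units; beyond the scatter). The modest step of a 3.2-fold higher number from compound 1 to compound 2 (0.50 log units; beyond the scatter) lies elsewhere and bears little. Compound 4 keeps a group on that nitrogen, as compound 3 does at > 100 mg/kg, so no change beyond the scatter is expected. The expected step is a number no higher from compound 3 to compound 4 (the limit leaves the size open). For compound 4 the estimate is 100 mg/kg, with an expected range from 35 mg/kg to 300 mg/kg.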

Compound 4, dose for 50% inhibition: > 100 mg/kg
Compound 4 was reported as a limit; the forecaster's own chance of this, stated with the estimate: 55%; the middle value lies on the limit itself.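

In this assay, methylsulfonyl in place of hydrogen on the nitrogen gives an at least 12-fold higher number from compound 1 to compound 4 (1.10 log units; beyond the scatter), so the large step at this nitrogen no longer rests on propanoyl alone. For compound 4, > 100 mg/kg is a limit of the assay and not a number. Whether methylsulfonyl and propanoyl differ cannot be read, because compound 3 and compound 4 both stand at that limit: the limit of > 100 mg/kg in this assay, at which 2 of the 4 values shown sit.

The compounds shown leave open whether a methyl group on this nitrogen, or a propanoyl chain carrying an amine, would stay near compound 1 or also reach the limit.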